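Removing the difluoromethyl group from the oxadiazole of compound 2

The source may report more compounds than this note shows. Statements on the series, on what has been measured and on what is new or still open speak of the compounds shown alone.

Measured compounds:
compound 1 `C[C@H](CN1CCC(F)CC1)NC(=O)c1ccc(-c2noc(C(F)(F)F)n2)cc1` gives 30 nM
compound 2 `CCCN(CCC)C[C@@H](C)NC(=O)c1ccc(-c2noc(C(F)F)n2)cc1` gives 890 nM

In an assay on isolated protein for inhibition of histone deacetylase 4 (Homo sapiens), read by fluorescence (on this read-out lower numbers stand for stronger inhibition and higher numbers for weaker inhibition), compound 2 gives 890 nM, the higher of the two numbers recorded so far. Compound 1 gives 30 nM, and the gap between these two numbers is well beyond the usual scatter of repeated measurements.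

Compound 3 `CCCN(CCC)C[C@@H](C)NC(=O)c1ccc(-c2ncon2)cc1` differs from compound 2 in one place: hydrogen in place of difluoromethyl on an aromatic carbon, so that 5-(difluoromethyl)-1,2,4-oxadiazol-3-yl becomes 1,2,4-oxadiazol-3-yl. Among the measured compounds shown here, no measured pair shows this change, so the expectation rests only on where compound 2 stands at 890 nM. The step from compound 2 to compound 3 is expected to raise the number, by a 10-fold higher number from compound 2 to compound 3 (1.00 log units; beyond the scatter), beyond the scatter. Compound 3 is therefore estimated at 9000 nM, with a range from 2000 nM to 40000 nM.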

Compound 3, half-maximal inhibitory concentration: > 50000 nM
Compound 3: a limit, no number (the forecaster's own chance of this, stated with the estimate: 30%); middle value at least 5.5-fold (0.74 log units) away from the limit.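

In this assay, hydrogen in place of difluoromethyl on this aromatic carbon gives an at least 56-fold higher number from compound 2 to compound 3 (1.74 log units; beyond the scatter). Compound 3 reaches only a limit of the assay, not a number, so this step has a floor but no known full size: the limit of > 50000 nM in this assay, at which 1 of the 3 values shown sits. Among the compounds shown here, the earlier compounds both carry a fluorinated carbon group at this position, so only this pair shows that, with the rest of compound 2 unchanged, the group on this carbon cannot be removed without a large loss of inhibition.

On these data alone, whether a plain methyl group, which keeps the carbon but has no fluorine, would retain any of that inhibition remains open. Compound 1 and compound 2 differ in more than one place, so how much trifluoromethyl and difluoromethyl differ from each other at this position also remains unsettled.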